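A few compounds are considered here, and "the series" means these few. Any claim that something is new, unique, unknown or untested is made for them only; others in the source may bear on it.

Compound 1 `Cc1c(O)nc(SCc2ccc(O)cc2)nc1Cc1c(Cl)cccc1Cl` gives 41000 nM in a functional assay on MT4 cells (Homo sapiens) for cytotoxicity, read by MTT assay; a lower number here means that less compound is tolerated, a higher number that more compound is tolerated. Compound 2 `COc1ccc(CSc2nc(O)c(C)c(Cc3ccc(F)cc3)n2)cc1` gives 8900 nM. Compound 3 `CCOc1ccc(CSc2nc(O)c(C)c(Cc3c(Cl)cccc3Cl)n2)cc1` gives only a limit of the assay, > 58000 nM.

Compound 3 therefore stands at the top of what this assay reports: it sits at the limit of > 58000 nM in this assay, at which 1 of the 3 values shown sits, so its true value is known only as a limit and not as a number. Among the measured compounds shown here, the one measured step that touches it, an at least 1.4-fold higher number from compound 1 to compound 3 (0.15 log units; that floor lies within the scatter), introduced ethyl in place of hydrogen on an oxygen on an aromatic ring, and even its floor lies within the usual scatter.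

Compound 4 `Cc1c(O)nc(SCc2ccccc2)nc1Cc1c(Cl)cccc1Cl` has not yet been measured. It differs from compound 3 by hydrogen in place of ethoxy on an aromatic carbon. For the measured compounds named here, no measured step removes the whole group in this way; the only guide is that compound 1, which also lacks the ethyl, gives 41000 nM. The step of an at least 1.6-fold lower number from compound 3 to compound 4 (0.21 log units; that floor lies within the scatter) is therefore expected to be small or modest. Compound 4 is estimated at 35000 nM, between 12000 nM and 80000 nM.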

Compound 4, half-maximal cytotoxic concentration: > 64000 nM
Compound 4 gave a limit, no number; the forecaster's own chance of this, stated with the estimate: 30%; middle value at least 1.8-fold (0.26 log units) away from the limit.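

In this assay compound 4 gives only a limit, > 64000 nM, so the bare phenyl also reaches the top of what the assay reports: the limit of > 64000 nM in this assay, at which 1 of the 4 values shown sits. Compound 3 and compound 4 are both limits, and the step between them cannot be read. Hydrogen in place of hydroxy gives an at least 1.5-fold higher number from compound 1 to compound 4 (0.19 log units; that floor lies within the scatter), so on this core the change among hydroxy, ethoxy and hydrogen at this position has not yet produced a step clearly beyond the scatter.

From the compounds shown here alone, the true values of compound 3 and compound 4 stay unknown, and so does their order. Also open, going by these compounds, is whether an amine or a carboxylic acid at this same position would leave the number near these values or bring it clearly lower.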